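The source may report more compounds than this note shows. Statements on the series, on what has been measured and on what is new or still open speak of the compounds shown alone.

Compound 1 `C/C(=N\NC(N)=S)c1sc(-c2ccccc2)nc1C`: 26 ug/mL
Compound 2 `C/C(=N\Nc1nc(-c2ccc(F)cc2)cs1)c1sc(C)nc1C`: > 100 ug/mL
Compound 3 `C/C(=N\Nc1nc(-c2ccc(Cl)cc2)cs1)c1sc(C)nc1C`: > 100 ug/mL

In a toxicity assay on MCF7 cells (Homo sapiens) for cytotoxicity, read by MTT assay (on this read-out lower numbers stand for stronger inhibition of growth and higher numbers for weaker inhibition of growth), compound 1 gives 26 ug/mL. Compound 2 gives > 100 ug/mL, which is a limit of the assay and not a number. Compound 3 gives > 100 ug/mL, also only a limit. Compound 3 therefore stands at the limit of > 100 ug/mL in this assay, at which 2 of the 3 values shown sit.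

Compound 4 `C/C(=N\Nc1nc(-c2ccc(C)cc2)cs1)c1sc(C)nc1C` has methyl in place of chloro on an aromatic carbon, 4-chlorophenyl becoming 4-methylphenyl: methyl in place of chloro on an aromatic carbon. Within the data shown here, the one measured step that bears on this is a step that the two limits leave unreadable from compound 2 to compound 3, with chloro in place of fluoro on an aromatic carbon. It offers no size to carry over, so no step beyond the scatter is expected in this assay, and no direction is favoured. The expected change is a number no higher from compound 3 to compound 4 (the limit leaves the size open). Compound 4 is estimated at 100 ug/mL, with an expected range of 50 ug/mL to 200 ug/mL.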

Compound 4, concentration for 50% growth inhibition: > 100 ug/mL
Compound 4 was reported as a limit (the forecaster's own chance of this, stated with the estimate: 70%); the middle value sits exactly at the limit.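

In this assay, compound 4 gives only a limit, as do compound 2 and compound 3, so no step among these three can be read: the limit of > 100 ug/mL in this assay, at which 3 of the 4 values shown sit.

As far as these compounds go, whether 4-fluorophenyl, 4-chlorophenyl and 4-methylphenyl differ at all in this read-out stays open.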